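Solubility notes: replacing the ring-nitrogen substituent on the shared core

The source may hold more compounds than are shown below. What is called first, only, known or untested is meant among the compounds shown, and "the series" means these compounds.

Compound 1 `O=C(c1cccnc1)N1CCC(NS(=O)(=O)c2cc(S(=O)(=O)c3ccccc3)ccc2C(F)(F)F)CC1` gives 50000 nM in a physicochemical assay for solubility; on this read-out lower numbers stand for lower solubility and higher numbers for higher solubility. Compound 2 `O=C(O)c1ccc(N2CCC(NS(=O)(=O)c3cc(S(=O)(=O)c4ccccc4)ccc3C(F)(F)F)CC2)cc1` gives 25000 nM in the same read-out. The step between them is a 2.0-fold lower number from compound 1 to compound 2 (0.30 log units; within the scatter), a change at the amine nitrogen of the six-membered ring. For the measured compounds named here, compound 2 therefore holds the lowest of the two numbers, with compound 1 as its only neighbour, and the step between them is within the scatter.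

Compound 3 `O=C([C@@H]1CCNC1)N1CCC(NS(=O)(=O)c2cc(S(=O)(=O)c3ccccc3)ccc2C(F)(F)F)CC1` has not yet been measured in this assay. Its change from compound 2 is (pyrrolidin-3-yl)carbonyl in place of 4-carboxyphenyl on an amine nitrogen in a ring. Going by the values given here, the only measured step that bears on this position is the one from compound 1 to compound 2, which was within the scatter; no other substituent at this amine nitrogen has been measured, so the data give no direction. The expectation is for a step of a 1.6-fold higher number from compound 2 to compound 3 (0.20 log units; within the scatter), not resolved beyond the scatter, because the precedent at this position, a 2.0-fold lower number from compound 1 to compound 2 (0.30 log units; within the scatter), was itself within it. Compound 3 is estimated at 40000 nM, with a range from 12000 nM to 130000 nM.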

Compound 3, solubility: 12500 nM
For compound 3 the middle estimate is 3.2-fold (0.51 log units) above the measured one, and the stated range covers the measured number.
By their numbers in this assay, from the lowest: compounds 3, 2 and 1 (each within the scatter of the next, the first and the last beyond it).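

Notes on the carbonyl carbon: the change from pyridin-3-yl to pyrrolidin-3-yl gives a 4.0-fold lower number from compound 1 to compound 3 (0.60 log units; beyond the scatter) in this assay and is the first single change at this amine nitrogen to lie beyond the scatter, though the step is modest. The other new step, a 2.0-fold lower number from compound 2 to compound 3 (0.30 log units; within the scatter), stays within the scatter, as did the earlier step at this position, so 4-carboxyphenyl is separated from neither carbonyl-linked group, while those two groups are separated from each other. There is no measurement in hand that accounts for this difference.

The compounds shown do not tell apart the contributions of the ring nitrogen, the five-membered non-aromatic ring and the defined stereocentre of the (pyrrolidin-3-yl)carbonyl group, since all three enter together. An open-chain amine on the same carbonyl carbon, or the opposite configuration at that stereocentre, would bear on this, and a carboxylic acid on a carbonyl-linked ring would show whether 4-carboxyphenyl stays unseparated from these groups when the carbonyl link is kept.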